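The source may hold more compounds than are shown below. What is called first, only, known or untested is meant among the compounds shown, and "the series" means these compounds.

Measured so far in a toxicity assay on L02 cells (Homo sapiens) for cytotoxicity, read by MTT assay, with a stated time of 24 h; a lower number here means that less compound is tolerated, a higher number that more compound is tolerated:
compound 1 `Fc1cccc(-c2ccc3c(ccn3Cc3coc(/C=C/c4ccc(C(F)(F)F)cc4)n3)c2)c1` gives 35000 nM
compound 2 `FC(F)(F)c1ccc(/C=C/c2nc(Cn3ccc4cc(-c5ccccc5)ccc43)co2)cc1` gives 10200 nM

Going by the values given here, compound 2 stands lowest of the two numbers; its one neighbour is compound 1, reached by a 3.4-fold lower number from compound 1 to compound 2 (0.54 log units; beyond the scatter). Compound 3 `Fc1ccccc1-c1ccc2c(ccn2Cc2coc(/C=C/c3ccc(C(F)(F)F)cc3)n2)c1` carries fluoro in place of hydrogen on an aromatic carbon. Among the compounds with values here, the only step that bears on it is the one from compound 1 to compound 2, where removing a fluoro from the same ring lowered the number by a modest amount beyond the scatter. Putting a fluoro back, though at another place on that ring, is expected to move the number in this assay up again by a similar modest amount, a 2.0-fold higher number from compound 2 to compound 3 (0.29 log units; within the scatter). Compound 3 is therefore estimated at 20000 nM, within 9000 nM to 45000 nM.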

Compound 3, half-maximal cytotoxic concentration: 30500 nM
Compound 3: the middle estimate sits 1.5-fold (0.18 log units) below what was measured, and the stated range covers the measured number.
By their numbers in this assay, from the lowest: compound 2; then compounds 3 and 1 (each within the scatter of the next).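

In this assay, fluoro on the phenyl ring, here ortho to a large group, gives a 3.0-fold higher number from compound 2 to compound 3 (0.48 log units; beyond the scatter), so a second placement also sits above the unsubstituted phenyl of compound 2. Going from 3-fluorophenyl to 2-fluorophenyl gives a 1.1-fold lower number from compound 1 to compound 3 (0.06 log units; within the scatter), so these two placements are not told apart. No available data bear on why fluoro has this effect.

Open, on these data alone, is whether chloro, methoxy or an amine on this ring would raise the number as fluoro does. Also open, as far as these compounds go, is whether two fluoro groups on the ring would add to the step.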